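The source may hold more compounds than are shown below. What is called first, only, known or untested is meant among the compounds shown, and "the series" means these compounds.

Among the compounds with values here, in a functional assay on MCF7 cells (Homo sapiens) for cytotoxicity, read by sulforhodamine B assay, with a stated time of 48 h (a higher number here means a weaker inhibitor of growth, a lower number a stronger inhibitor of growth), compound 1 `CCN(CC)CN1C(=O)/C(=N\c2nc3ccc(C)cc3s2)c2ccccc21` gives 74800 nM, while compound 2 `Cc1ccc2nc(/N=C3\C(=O)N(CN4CCCCC4)c4ccccc43)sc2c1` gives 37800 nM; the only single-point step among the measured compounds, a 2.0-fold lower number from compound 1 to compound 2 (0.30 log units; within the scatter), stays within the scatter. Compound 3 `Cc1ccc2nc(/N=C3\C(=O)N(CN(C)C)c4cccc(Br)c43)sc2c1` gives 18000 nM, the lowest of the three numbers, separated beyond the scatter from both compound 2 and compound 1. Compound 4 `Cc1ccc2nc(/N=C3\C(=O)N(CN(C)C)c4ccccc43)sc2c1` differs from compound 3 by hydrogen in place of bromo on an aromatic carbon. Within the data shown here, no measured step concerns this change: the one step at hand alters the amine side chain and not the aromatic ring, so nothing among the measured pairs fixes the size of this step. One expects the number to rise moderately, an estimated step of a 2.0-fold higher number from compound 3 to compound 4 (0.30 log units; within the scatter), with a wide band of uncertainty. Compound 4 is thus estimated at 36000 nM, between 12000 nM and 100000 nM.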

Compound 4, concentration for 50% growth inhibition: 29200 nM
Estimate against measurement, compound 4: 1.2-fold (0.09 log units) above, within the range that was stated.
By their numbers in this assay, from the lowest: compounds 3, 4, 2 and 1 (each within the scatter of the next, the first and the last beyond it).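

In this assay, hydrogen in place of bromo on this aromatic carbon gives a 1.6-fold higher number from compound 3 to compound 4 (0.21 log units; within the scatter) and so leaves the two compounds unresolved. Within the data shown here, on the side chain, dimethylamino in place of piperidin-1-yl gives a 1.3-fold lower number from compound 2 to compound 4 (0.11 log units; within the scatter) and is equally unresolved, while dimethylamino in place of diethylamino gives a 2.6-fold lower number from compound 1 to compound 4 (0.41 log units; beyond the scatter) as the first single-place step beyond the scatter, though a modest one. No supporting measurement bears on any of these steps. Going by these compounds, whether chloro or methoxy on this aromatic carbon would separate from hydrogen or bromo remains open. Also open, on these data alone, is whether bromo would count for more with piperidin-1-yl or diethylamino on the side chain.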